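Replacing bromo with hydroxy in compound 3

The source may hold more compounds than are shown below. What is called first, only, known or untested is meant among the compounds shown, and "the series" means these compounds.

In a functional assay on L1210 cells (Mus musculus) for inhibition, read by MTT assay, with a stated time of 72 h (a higher number here means a weaker inhibitor, a lower number a stronger inhibitor), compound 1 (`COc1cc(NC(C)CCCNC(=O)Nc2cccc(Cl)c2)c2ncccc2c1`) gives 17000 nM and compound 2 (`COc1cc(NC(C)CCCNC(=O)Nc2ccc(F)cc2)c2ncccc2c1`) gives 18000 nM as its reading. Compound 3 (`COc1cc(NC(C)CCCNC(=O)NNC(=O)Nc2ccc(Br)cc2)c2ncccc2c1`) gives 51000 nM as the highest number of the three, which makes it the weakest inhibitor here. The measured steps leading to it are a 3.0-fold higher number from compound 1 to compound 3 (0.48 log units; beyond the scatter) and a 2.8-fold higher number from compound 2 to compound 3 (0.45 log units; beyond the scatter), and both replace a whole aryl group with ((4-bromophenyl)carbamoyl)amino.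

Compound 4 (`COc1cc(NC(C)CCCNC(=O)NNC(=O)Nc2ccc(O)cc2)c2ncccc2c1`) departs from compound 3 in one place, and hydroxy in place of bromo on an aromatic carbon is the entire difference, with hydroxy in place of bromo on an aromatic carbon. For the measured compounds named here, the closest precedent is the exchange of 3-chlorophenyl for 4-fluorophenyl, which gave a 1.1-fold higher number from compound 1 to compound 2 (0.02 log units; within the scatter) and so changed the aryl substituent without a step beyond the scatter. Going by the values given here, no measured compound carries hydroxy, so this precedent is thin.

A step within the scatter is therefore expected, and the estimated step is a 1.3-fold lower number from compound 3 to compound 4 (0.11 log units; within the scatter) in this comparison. Compound 4 is estimated at 40000 nM as a middle value, with an expected range from 15000 nM up to 100000 nM in this assay.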

Compound 4, half-maximal inhibitory concentration: 95000 nM
Beside the measured number, compound 4's estimate is 2.4-fold (0.38 log units) below it; the range from low to high includes it.
By their numbers in this assay, from the lowest: compounds 1 and 2 (each within the scatter of the next); then compounds 3 and 4 (each within the scatter of the next).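

In this assay the aryl substituent is now varied with the ((aryl)carbamoyl)amino group held in place, and hydroxy in place of bromo, on an aromatic carbon para to a large group, gives a 1.9-fold higher number from compound 3 to compound 4 (0.27 log units; within the scatter) and so does not separate the two compounds, although hydroxy brings a hydrogen-bond donor and acceptor that bromo lacks. The gap to the plain aryl compounds persists with hydroxy, at a 5.3-fold higher number from compound 2 to compound 4 (0.72 log units; beyond the scatter) and a 5.6-fold higher number from compound 1 to compound 4 (0.75 log units; beyond the scatter) and both beyond the scatter, so compounds 3 and 4 alike read higher than compounds 1 and 2. No evidence is available to explain these readings.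

The compounds shown leave open whether an amine or a carboxylic acid at this same place would stay within the scatter of compound 3. They also leave open how hydroxy would read on the 4-fluorophenyl group of compound 2, without the added carbamoyl-amino link.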